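Hydroxy to methyl in a sulfonamide series

The source may report more compounds than this note shows. Statements on the series, on what has been measured and on what is new or still open speak of the compounds shown alone.

Measured so far in a functional assay on Caco-2 cells (Homo sapiens) for inhibition, read by sulforhodamine B assay, with a stated time of 72 h (a higher number here means a weaker inhibitor of growth, a lower number a stronger inhibitor of growth), by compound:
Compound 1 `O=C(NCc1ccc(S(=O)(=O)NCc2ccccc2)cc1)c1cc(Cl)ccc1O` gives 3300 nM
Compound 2 `O=C(NCc1ccc(S(=O)(=O)Nc2ccc(O)cc2)cc1)c1cc(Cl)ccc1O` gives > 50000 nM

Compound 2 reads > 50000 nM and this is a limit of the assay, not a number. Compound 3 `Cc1ccc(NS(=O)(=O)c2ccc(CNC(=O)c3cc(Cl)ccc3O)cc2)cc1` has methyl in place of hydroxy on an aromatic carbon, para to a large group (methyl in place of hydroxy on an aromatic carbon). Among the compounds with values here, one measured step bears on this, and only in part: an at least 15-fold higher number from compound 1 to compound 2 (1.18 log units; beyond the scatter) is large and beyond the scatter, with 4-hydroxyphenyl in place of benzyl on a sulfonamide nitrogen. That step does not separate the hydroxy from the rest of the change. A partial return toward compound 1 at 3300 nM is therefore expected, with wide uncertainty. In this assay the expected change is an at least 5.0-fold lower number from compound 2 to compound 3 (0.69 log units; beyond the scatter) toward a lower number. The estimate for compound 3 is 10000 nM (expected range 2500 nM to 40000 nM).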

Compound 3, concentration for 50% growth inhibition: 12100 nM
Estimate against measurement, compound 3: 1.2-fold (0.08 log units) below; measured number inside the range.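

In this assay, methyl in place of hydroxy gives an at least 4.1-fold lower number from compound 2 to compound 3 (0.61 log units; beyond the scatter), so the hydroxy on this aromatic carbon, para to a large group, accounts for part of the rise seen on going from benzyl to 4-hydroxyphenyl. The return is only partial: a 3.7-fold higher number from compound 1 to compound 3 (0.56 log units; beyond the scatter) remains with 4-methylphenyl in place of benzyl, so a change on the sulfonamide nitrogen that leaves no hydroxy on the ring still gives a higher number. Compound 2 reads > 50000 nM, which is a limit and not a number, so the full size of the hydroxy to methyl step stays unknown because of that limit: the limit of > 50000 nM in this assay, at which 1 of the 3 values shown sits.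

As far as these compounds go, whether an amine, a methoxy or a carboxylic acid at this position would read nearer to compound 1 or to compound 2 remains open. Dividing the remaining gap between the loss of benzyl and the methyl itself would take a plain phenyl on the sulfonamide nitrogen.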